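Swapping pyridin-2-yl for furan-2-yl on a shared core

A few compounds are considered here, and "the series" means these few. Any claim that something is new, unique, unknown or untested is made for them only; others in the source may bear on it.

Compound 1 `c1ccc(-c2cc(-c3cccs3)nc(-c3cccs3)c2)nc1`: 118000 nM
Compound 2 `c1ccc(-c2cc(-c3cccs3)cc(-c3ccco3)n2)cc1`: 118000 nM
Compound 3 `c1coc(-c2ccnc(-c3ccco3)c2)c1`: 118000 nM

Of the compounds shown here, three have so far been tested in a functional assay on HCT-15 cells (Homo sapiens) for antiproliferative activity; a higher number here means that more compound is needed for the effect, a lower number that less compound is needed. Compound 1 gives 118000 nM in this assay. Compound 2 gives 118000 nM, and compound 3 gives 118000 nM. At the digits shown, compound 1 stands level with compound 2 and with compound 3; the nearest and the furthest of the others are both within the scatter of it, so nothing in these three numbers separates one compound from another.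

The next compound, compound 4 `c1coc(-c2cc(-c3cccs3)nc(-c3cccs3)c2)c1`, has not yet been measured. Compared with compound 1 it carries one change: furan-2-yl in place of pyridin-2-yl on an aromatic carbon. The place of the change is on an aromatic carbon of the core, meta to two thiophen-2-yl groups and opposite the ring nitrogen.

Among the compounds with values here, no pair of measured compounds differs in exactly one place, so there is no measured step to lean on. Since compounds 1, 2 and 3 all sit at the same value in this assay despite differing in several places, the expectation for compound 4 is a step from compound 1 of no change at the digits printed from compound 1 to compound 4 (within the scatter), that is, none beyond the scatter. Compound 4 is therefore estimated at 118000 nM, with a range from 55000 nM to 250000 nM.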

Compound 4, half-maximal effective concentration: 118000 nM
For compound 4 middle estimate and measured number coincide at the digits printed; low and high end bracket the measured number.
By their numbers in this assay, from the lowest: compounds 1, 2, 3 and 4 (each within the scatter of the next).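

Within the data shown here, this is the first pair of compounds that differs in exactly one place, so this position can now be read directly: in this assay, furan-2-yl in place of pyridin-2-yl on an aromatic carbon gives a step of no change at the digits printed from compound 1 to compound 4 (within the scatter). At this place, on the carbon opposite the ring nitrogen of the shared core, the read-out therefore does not separate a six-membered aromatic ring from a five-membered one, even though the hetero atom in the swapped ring changes from nitrogen to oxygen. No measured property of either group is available to bear on this result.

The compounds shown leave open whether this position responds to any group of a different kind, such as an aminomethyl group, a carboxylic acid or a longer alkyl chain, since both groups compared here are single aromatic rings. They also leave open what a single change to either thiophen-2-yl group would do, with the rest of compound 1 kept the same.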